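Second fluoro for methoxy on the cinnamoyl aryl ring

The compounds below may be only part of what the source reports. "The series", "measured", "known", "first", "only" and "open" are said of these compounds alone.

Compound 2 `COc1cc(/C=C/C(=O)Nc2cc(C(=O)c3cc(OC)c(OC)c(OC)c3)ccc2OC)ccc1F` gives the highest of the two numbers here in a functional assay on PC-3 cells (Homo sapiens) for cytotoxicity, read by MTT assay, with a stated time of 72 h; a higher number here means a weaker inhibitor, a lower number a stronger inhibitor; its nearest neighbour is compound 1 `COc1ccc(C(=O)c2cc(OC)c(OC)c(OC)c2)cc1NC(=O)/C=C/c1ccc(OC)c(OC)c1`, which gives 7500 nM against 14100 nM for compound 2. Compound 3 `COc1ccc(C(=O)c2cc(OC)c(OC)c(OC)c2)cc1NC(=O)/C=C/c1ccc(F)c(F)c1` differs from compound 2 by fluoro in place of methoxy on an aromatic carbon. Going by the values given here, the one step that bears on this is a 1.9-fold higher number from compound 1 to compound 2 (0.27 log units; within the scatter), the same kind of exchange at the neighbouring position, and it stayed within the scatter. A similar small shift, if any, is expected: a 1.3-fold higher number from compound 2 to compound 3 (0.11 log units; within the scatter). Compound 3 is therefore estimated at 18000 nM, with a range from 7000 nM to 45000 nM in this assay.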

Compound 3, half-maximal inhibitory concentration: 8300 nM
For compound 3 the middle estimate is 2.2-fold (0.34 log units) above the measured one; low and high end bracket the measured number.
By their numbers in this assay, from the lowest: compounds 1, 3 and 2 (each within the scatter of the next).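

In this assay, fluoro in place of the remaining methoxy gave a 1.7-fold lower number from compound 2 to compound 3 (0.23 log units; within the scatter) and so, like the first exchange, stayed within the scatter. The full change to 3,4-difluorophenyl from 3,4-dimethoxyphenyl gave a 1.1-fold higher number from compound 1 to compound 3 (0.04 log units; within the scatter) and thus also left no readable difference, whether one methoxy or both were exchanged. Nothing available explains this result.

On these data alone, whether an amine, a carboxylic acid or a longer chain at this place would give a step beyond the scatter remains open.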